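Methyl in Place of Hydrogen Carried to a Second Core

This account rests on a few compounds, and the source may have more. Where it says the series, first, only, none or still open, it means among the compounds named here.

Measured compounds:
compound 1 `Cc1nc2nc(-c3ccccc3)cc(C(F)(F)F)c2c(=O)n1Cc1cn(CCC(F)(F)C(F)(F)C(F)(F)C(F)(F)C(F)(F)C(F)(F)F)nn1` gives > 200 ug/mL
compound 2 `CCCCCCCCCCn1cc(Cn2c(C)nc3nc(-c4ccccc4)cc(C(F)(F)F)c3c2=O)nn1` gives 11.3 ug/mL
compound 3 `CCc1nc2nc(-c3ccccc3)cc(C(F)(F)F)c2c(=O)n1Cc1cn(CCC(F)(F)C(F)(F)C(F)(F)C(F)(F)C(F)(F)C(F)(F)F)nn1` gives > 200 ug/mL

In a functional assay on THP-1 cells (Homo sapiens) for cytotoxicity, read by MTT assay, with a stated time of 24 h (a lower number here means a stronger inhibitor, a higher number a weaker inhibitor), compound 1 gives only a limit, > 200 ug/mL. Compound 3 also gives only a limit, > 200 ug/mL. Compound 3 differs from compound 1 by methyl in place of hydrogen on a saturated chain carbon bound to an aromatic carbon. The step that the two limits leave unreadable from compound 1 to compound 3 cannot be read because both values sit at the limit of > 200 ug/mL in this assay, at which 2 of the 3 values shown sit. Compound 2 gives 11.3 ug/mL in this assay; how its core differs from the core of compound 1 is not broken down here. Compound 4 `CCCCCCCCCCn1cc(Cn2c(CC)nc3nc(-c4ccccc4)cc(C(F)(F)F)c3c2=O)nn1` differs from compound 2 by the same change, (methyl in place of hydrogen on a saturated chain carbon bound to an aromatic carbon). The measured pair offers no readable size for this change, so the expectation for compound 4 rests on compound 2, which gives 11.3 ug/mL. Compound 4 is therefore expected to give 12 ug/mL, from 5 ug/mL to 35 ug/mL, an expected step of a 1.1-fold higher number from compound 2 to compound 4 (0.03 log units; within the scatter) that stays within the usual scatter.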

Compound 4, half-maximal inhibitory concentration: 82.7 ug/mL
Compound 4: the middle estimate sits 6.9-fold (0.84 log units) below what was measured, and the stated range ends below it.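

On the core of compound 2, methyl in place of hydrogen on a saturated chain carbon bound to an aromatic carbon gives a 7.3-fold higher number from compound 2 to compound 4 (0.86 log units; beyond the scatter) in this assay. On the core of compound 1 the same change cannot be read, because compound 1 and compound 3 both rest on a limit rather than a number: the limit of > 200 ug/mL in this assay, at which 2 of the 4 values shown sit. The size is therefore known on one core only, and this single pair does not show whether it carries from one core to another.

The compounds shown leave open whether propyl, or an amine, on that saturated chain carbon would shift the number further on the core of compound 2. As far as these compounds go, whether any such change would bring the core of compound 1 to a readable value also stays open.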